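A few compounds are considered here, and "the series" means these few. Any claim that something is new, unique, unknown or untested is made for them only; others in the source may bear on it.

Compound 1 `CCCCc1cn(C[C@H](O)[C@H]2OC(=O)C(OCc3ccccc3)=C2OCc2ccccc2)nn1`: 47500 nM
Compound 2 `O=C1O/C(=C\Cn2cc(-c3cc(C(F)(F)F)cc(C(F)(F)F)c3)nn2)C(OCc2ccccc2)=C1OCc1ccccc1`: > 100000 nM

Of the compounds shown here, two have been measured in a functional assay on SW-620 cells (Homo sapiens) for antiproliferative activity, read by MTT assay, with a stated time of 72 h; on this read-out higher numbers stand for weaker inhibition and lower numbers for stronger inhibition. Going by the values given here, compound 1 gives 47500 nM, the only number reported. Among the compounds with values here, for compound 2 the result > 100000 nM is a limit and not a number. the limit of > 100000 nM in this assay, at which 1 of the 2 values shown sits, marks where one of the two results sits, so compound 1 stands as the sole measured figure, and no step between measured compounds can be drawn.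

Compound 3 `COc1ccc(-c2cn(C[C@H](O)[C@H]3OC(=O)C(OCc4ccccc4)=C3OCc3ccccc3)nn2)cc1` differs from compound 1 by 4-methoxyphenyl in place of butyl on an aromatic carbon. Within the data shown here, with no measured step to lean on, the expectation is that this change moves the read-out in this assay little or weakens inhibition slightly, the step from compound 1 to compound 3 being estimated at a 1.3-fold higher number from compound 1 to compound 3 (0.10 log units; within the scatter). Compound 3 is therefore expected to give 60000 nM, within 20000 nM to 150000 nM, with a fair chance that only a limit is reported.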

Compound 3, half-maximal inhibitory concentration: 58200 nM
Compound 3: middle estimate off by 1.0-fold (0.01 log units), on the high side; measured number inside the range.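

Going by these compounds alone, this is the first step that can be read at this position, on an aromatic carbon of the five-membered aromatic ring with 3 nitrogen: in this assay, 4-methoxyphenyl in place of butyl gives a 1.2-fold higher number from compound 1 to compound 3 (0.09 log units; within the scatter). The position thus accepts a group with more heavy atoms, a six-membered aromatic ring and a hydrogen-bond acceptor, and compound 1 and compound 3 cannot be told apart on this read-out. Nothing measured here gives a reason for this outcome.

On these data alone, it remains open whether an amine or a carboxylic acid at this position would separate from compound 1 and compound 3 beyond the usual scatter. A chain longer than butyl, or a phenyl ring without the methoxy group, is equally untested by the compounds shown here.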